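Substituent at the aromatic carbon of the shared core

The source may hold more compounds than are shown below. What is called first, only, known or untested is meant among the compounds shown, and "the series" means these compounds.

Measured so far:
compound 1, `COc1ccc2nc(NC(=O)CCCCCCC(=O)NO)sc2c1`: 0.79 ug/mL
compound 2, `O=C(CCCCCCC(=O)Nc1nc2ccccc2s1)NO`: 5.69 ug/mL
compound 3, `CCOc1ccc2nc(NC(=O)CCCCCCC(=O)NO)sc2c1`: 9.88 ug/mL

In a functional assay on ASPC1 cells (Homo sapiens) for cytotoxicity (on this read-out higher numbers stand for weaker inhibition and lower numbers for stronger inhibition), compound 3 gives the highest of the three numbers. Its nearest neighbour is compound 2, a step of a 1.7-fold higher number from compound 2 to compound 3 (0.24 log units; within the scatter); its furthest is compound 1, a step of a 13-fold higher number from compound 1 to compound 3 (1.10 log units; beyond the scatter).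

Compound 4, `Cc1ccc2nc(NC(=O)CCCCCCC(=O)NO)sc2c1`, differs from compound 3 by methyl in place of ethoxy on an aromatic carbon.

Among the measured compounds shown here, no compound with a methyl on this aromatic carbon has been measured, so the step to compound 4 has no direct precedent. What bears on it is that the ethoxy of compound 3 sits close to the hydrogen of compound 2 (a 1.7-fold higher number from compound 2 to compound 3 (0.24 log units; within the scatter)), while the methoxy of compound 1 stands well apart from both (a 7.2-fold higher number from compound 1 to compound 2 (0.86 log units; beyond the scatter)). A methyl is expected to behave more like the hydrogen or the ethoxy than like the methoxy, so a small step downward in this assay is expected for compound 4, a 2.2-fold lower number from compound 3 to compound 4 (0.34 log units; beyond the scatter), with wide uncertainty. For compound 4 the expected value is 4.5 ug/mL, in the range 1.2 ug/mL to 15 ug/mL.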

Compound 4, half-maximal inhibitory concentration: 0.54 ug/mL
For compound 4 the middle estimate is 8.3-fold (0.92 log units) above the measured one; the whole stated range lies above it.
By their numbers in this assay, from the lowest: compounds 4 and 1 (each within the scatter of the next); then compounds 2 and 3 (each within the scatter of the next).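

In this assay the methyl of compound 4 stands well apart from both the ethoxy (an 18-fold lower number from compound 3 to compound 4 (1.26 log units; beyond the scatter)) and the hydrogen (an 11-fold lower number from compound 2 to compound 4 (1.02 log units; beyond the scatter)), so a single carbon on this aromatic carbon is enough to separate the series from its unsubstituted member. Against the methoxy the methyl stays within the scatter (a 1.5-fold lower number from compound 1 to compound 4 (0.17 log units; within the scatter)), which shows that oxygen on this carbon is not required for the low numbers, while ethoxy, which also carries an oxygen, goes against any link between that atom and a low number. No measurement here accounts for the wide gap between the methoxy and methyl pair and the ethoxy.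

Going by these compounds, whether the low numbers extend to a chlorine, an amine or a carboxylic acid on this carbon remains open. Also open, on these data alone, is whether a propoxy chain would stay with the ethoxy.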